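The source may hold more compounds than are shown below. What is called first, only, known or untested is meant among the compounds shown, and "the series" means these compounds.

Compound 1 `O=C(c1ccccc1)N1CCC(NCCSC(c2ccc(F)cc2)c2ccc(F)cc2)CC1`: 2.03 nM
Compound 2 `O=C(c1cc2ccccc2o1)N1CCC(NCCSC(c2ccc(F)cc2)c2ccc(F)cc2)CC1`: 304 nM
Compound 3 `O=C(c1cc2ccccc2[nH]1)N1CCC(NCCSC(c2ccc(F)cc2)c2ccc(F)cc2)CC1`: 1130 nM

In an assay on membranes from Cortex for displacement of a labelled ligand from Sigma non-opioid intracellular receptor 1 (Cavia porcellus), read by scintillation counting, with a stated time of 120 min (on this read-out lower numbers stand for stronger inhibition and higher numbers for weaker inhibition), compound 3 gives the highest number of the three; both a 3.7-fold higher number from compound 2 to compound 3 (0.57 log units; beyond the scatter) and a 560-fold higher number from compound 1 to compound 3 (2.75 log units; beyond the scatter) lie beyond the scatter. Compound 4 `O=C(c1ccccc1F)N1CCC(NCCSC(c2ccc(F)cc2)c2ccc(F)cc2)CC1` differs from compound 3 in one place: 2-fluorophenyl in place of 1H-indol-2-yl on a carbonyl carbon. The step that bears most on this change is a 560-fold higher number from compound 1 to compound 3 (2.75 log units; beyond the scatter), a large rise on moving from phenyl to the indolyl group; the reverse move, back to a phenyl ring, here carrying a fluorine, should undo most of it. a 150-fold higher number from compound 1 to compound 2 (2.18 log units; beyond the scatter) points the same way. The step is therefore expected to be large and downward: a 320-fold lower number from compound 3 to compound 4 (2.51 log units; beyond the scatter). Compound 4 is expected to give about 3.5 nM in this assay, within 1 nM to 15 nM.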

Compound 4, inhibition constant: 3.57 nM
Compound 4: the middle estimate sits 1.0-fold (0.01 log units) below what was measured; measured number inside the range.
By their numbers in this assay, from the lowest: compounds 1 and 4 (each within the scatter of the next); then compound 2; then compound 3.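

In this assay, replacing 1H-indol-2-yl with 2-fluorophenyl gives a 320-fold lower number from compound 3 to compound 4 (2.50 log units; beyond the scatter), and replacing 1-benzofuran-2-yl with it gives an 85-fold lower number from compound 2 to compound 4 (1.93 log units; beyond the scatter), so the substituted phenyl ring also stands far from both of these groups. Fluoro in place of hydrogen on the aromatic carbon gives a 1.8-fold higher number from compound 1 to compound 4 (0.25 log units; within the scatter), showing that this ring can carry a fluorine with no difference beyond the scatter. Nothing available explains these steps.

On these data alone, whether chloro, methoxy or an amine on the phenyl ring would be accepted like fluoro remains open. So does whether a pyridyl ring would match phenyl here.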